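Pentan-3-yl for cyclohexylmethyl on the core nitrogen

This account rests on a few compounds, and the source may have more. Where it says the series, first, only, none or still open, it means among the compounds named here.

Of the compounds shown here, three have been measured in an assay on isolated protein for agonist activity at Bile acid receptor (Homo sapiens), read by TR-FRET; a higher number here means that more compound is needed for the effect, a lower number that less compound is needed. Compound 1 `CCC(CC)n1c(-c2ccc(OCc3c(-c4c(Cl)cccc4Cl)noc3C(C)C)cc2F)nc2ccc(C(=O)O)cc21` gives 69.3 nM, compound 2 `CCC(CC)n1c(-c2ccc(OCc3c(-c4c(Cl)cccc4Cl)noc3C(C)C)cc2)nc2ccc(C(=O)O)cc21` gives 26.5 nM, and compound 3 `CC(C)c1onc(-c2c(Cl)cccc2Cl)c1COc1ccc(-c2nc3ccc(C(=O)O)cc3n2CC2CCCCC2)c(Cl)c1` gives 66.1 nM. Going by the values given here, the only single-point step among them, a 2.6-fold lower number from compound 1 to compound 2 (0.42 log units; beyond the scatter), concerns the ring that carries the halogen, not the substituent on the core nitrogen. Compound 3 stands second highest of the three numbers, within the scatter of compound 1 and beyond the scatter above compound 2.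

Compound 4 `CCC(CC)n1c(-c2ccc(OCc3c(-c4c(Cl)cccc4Cl)noc3C(C)C)cc2Cl)nc2ccc(C(=O)O)cc21` is the next member. It differs from compound 3 by pentan-3-yl in place of cyclohexylmethyl on an aromatic nitrogen. Among the compounds with values here, no measured step bears on this change: the one step on record alters a different part of the molecule, and compound 4 keeps the chloro that compound 3 carries. The pentan-3-yl group itself is present on compounds 1 and 2, whose numbers differ from that of compound 3 by no more than the fluoro-to-hydrogen step. On that basis a step of a 1.1-fold higher number from compound 3 to compound 4 (0.02 log units; within the scatter) is expected, that is, no change beyond the scatter. The value of compound 4 in this assay is therefore estimated at 70 nM, with a range from 30 nM to 165 nM.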

Compound 4, half-maximal effective concentration: 21.6 nM
For compound 4 the middle estimate is 3.2-fold (0.51 log units) above the measured one; measured number outside the range, below it.
By their numbers in this assay, from the lowest: compounds 4 and 2 (each within the scatter of the next); then compounds 3 and 1 (each within the scatter of the next).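

In this assay, going by these compounds alone, with the chloro held constant, the change from cyclohexylmethyl to pentan-3-yl on the aromatic nitrogen gives a 3.1-fold lower number from compound 3 to compound 4 (0.49 log units; beyond the scatter), the first direct reading of this position. It shows that this nitrogen substituent can shift the number beyond the scatter, with an open-chain group and no ring in place of a ring-bearing one. With pentan-3-yl held constant, the halogen site can also be read more fully: chloro in place of hydrogen gives a 1.2-fold lower number from compound 2 to compound 4 (0.09 log units; within the scatter), which stays within the scatter, while chloro in place of fluoro gives a 3.2-fold lower number from compound 1 to compound 4 (0.51 log units; beyond the scatter), so among these three compounds only the fluoro compound stands apart. No available evidence explains either the nitrogen step or the halogen steps.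

Going by these compounds, the nitrogen step rests on a single pair carrying chloro, so its size with hydrogen or fluoro on that aromatic carbon remains open. On these data alone, how a straight pentyl chain, a cyclopentyl ring or a methoxyethyl chain on the same nitrogen would compare with pentan-3-yl also remains open.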